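The source may hold more compounds than are shown below. What is called first, only, known or untested is meant among the compounds shown, and "the series" means these compounds.

The measured compounds:
compound 1, `Cc1ccc(C(=O)n2c(-c3cn(-c4ccccc4)nc3-c3ccc(C(F)(F)F)cc3)nc3ccccc32)cc1`, 169000 nM
compound 2, `Cc1ccc(C(=O)n2c(-c3cn(-c4ccccc4)nc3-c3ccc(C(F)(F)F)cc3)nc3ccccc32)cn1`, 153000 nM
compound 3, `O=C(c1ccccc1)n1c(-c2cn(-c3ccccc3)nc2-c2ccc(C(F)(F)F)cc2)nc2ccccc21`, 168000 nM

These numbers come from an ADME assay on HEK-293T cells (Homo sapiens) for cytotoxicity, read by MTT assay, with a stated time of 24 h; on this read-out higher numbers stand for lower toxicity in this test and lower numbers for higher toxicity in this test. Compound 3 sits among three numbers that all lie within the scatter of one another: the step of a 1.0-fold lower number from compound 1 to compound 3 (0.00 log units; within the scatter) and the step of a 1.1-fold higher number from compound 2 to compound 3 (0.04 log units; within the scatter) are both too small to count as real differences.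

Compound 4, `O=C(c1cccnc1)n1c(-c2cn(-c3ccccc3)nc2-c2ccc(C(F)(F)F)cc2)nc2ccccc21`, has not been measured in this assay. It differs from compound 3 in one place: pyridin-3-yl in place of phenyl on a carbonyl carbon. Among the compounds with values here, one measured step bears on a change of this kind at the carbonyl carbon: a 1.1-fold lower number from compound 1 to compound 2 (0.04 log units; within the scatter), where 6-methylpyridin-3-yl took the place of 4-methylphenyl. That exchange of a carbon ring for a ring with one nitrogen left the number where it was. The change from compound 3 to compound 4 is the same kind of swap in the same place. No step beyond the scatter is expected, and a 1.0-fold lower number from compound 3 to compound 4 (0.01 log units; within the scatter) is the step the estimate means. For compound 4 the number expected in this assay is 165000 nM, within a range from 100000 nM to 270000 nM.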

Compound 4, half-maximal cytotoxic concentration: 158000 nM
Compound 4: the middle estimate sits 1.0-fold (0.02 log units) above what was measured, within the range that was stated.
By their numbers in this assay, from the lowest: compounds 2, 4, 3 and 1 (each within the scatter of the next).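

The exchange of phenyl for pyridin-3-yl on the carbonyl carbon can now be read without a methyl on the ring, and it gives a 1.1-fold lower number from compound 3 to compound 4 (0.03 log units; within the scatter). Removing the methyl from 6-methylpyridin-3-yl gives a 1.0-fold higher number from compound 2 to compound 4 (0.01 log units; within the scatter), and the combined exchange of 4-methylphenyl for pyridin-3-yl gives a 1.1-fold lower number from compound 1 to compound 4 (0.03 log units; within the scatter), so neither is a real difference. Removing the methyl also reads alike whether the ring holds a nitrogen or not: the same change on two cores in this assay, a 1.0-fold lower number (0.00 log units; within the scatter) from compound 1 to compound 3 and a 1.0-fold higher number (0.01 log units; within the scatter) from compound 2 to compound 4, 1.0-fold (0.02 log units) apart, within the scatter of two such steps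

Still open, going by these compounds, is whether this position stays as indifferent to a group of another kind, such as an amine or a carboxylic acid on the ring, or a longer chain in place of the methyl. On these data alone, the parts of the shared core away from the carbonyl are the same throughout, and what they contribute in this test stays unknown.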